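The source may report more compounds than this note shows. Statements on the series, on what has been measured and on what is new or still open speak of the compounds shown alone.

Measured so far in a functional assay on the whole organism (strain albino) for inhibition, with Rattus norvegicus as the target, read by paw edema, with stated times of 30 min and 2 h, at a dose of 100 mg/kg by the oral route; on this read-out lower numbers stand for less inhibition and higher numbers for more inhibition at the one dose given (going by the name of the read-out):
compound 1 `COc1ccc(C2=NN(C(=O)C(C)O[N+](=O)[O-])C(c3ccco3)C2)cc1OC` gives 39%
compound 2 `COc1ccc(C2CC(c3ccc(OC)c(OC)c3)=NN2C(=O)C(C)O[N+](=O)[O-])c(OC)c1` gives 61%
compound 3 `COc1ccc(C2=NN(C(=O)CNc3ccc(/C(C)=N/O)cc3)C(c3ccco3)C2)cc1OC` gives 46%

Compound 2 is obtained from compound 1 by 2,4-dimethoxyphenyl in place of furan-2-yl on a saturated ring carbon, and this single change gives a number 22 percentage points higher from compound 1 to compound 2 (beyond the scatter). Compound 3 differs from compound 1 in the group on the ring nitrogen; the difference between the two cores is not broken down here. Compound 3 and compound 1 read within the scatter of each other, while compound 2 stands beyond the scatter from compound 3.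

Compound 4 `COc1ccc(C2CC(c3ccc(OC)c(OC)c3)=NN2C(=O)CNc2ccc(/C(C)=N/O)cc2)c(OC)c1` is not yet measured; it is derived from compound 3 by 2,4-dimethoxyphenyl in place of furan-2-yl on a saturated ring carbon. For the measured compounds named here, this is the same kind of change as the one between compound 1 and compound 2, though the surroundings are described differently: in compound 1 the neighbouring ring atom bears a group of 8 heavy atoms and the ring atom two bonds away bears a large group, whereas in compound 3 the neighbouring ring atom bears a large group and the ring atom two bonds away bears a 3,4-dimethoxyphenyl group. Going by the values given here, only one earlier instance of the change exists, so the expectation rests on that alone. Among the compounds with values here, the step from compound 3 to compound 4 is expected to be a number 18 percentage points higher from compound 3 to compound 4 (beyond the scatter), resting on the one prior step a number 22 percentage points higher from compound 1 to compound 2 (beyond the scatter). Compound 4 is therefore estimated at 64%, in a range from 50% to 78%.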

Compound 4, a percentage reported as inhibition, in the whole organism at one dose (the size of the read-out at that dose, not a potency): 44%
Compound 4: middle estimate off by 20 percentage points, on the high side, outside the stated range (below it).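

Putting 2,4-dimethoxyphenyl in place of furan-2-yl on the saturated ring carbon gives, in this assay, a number 2 percentage points lower from compound 3 to compound 4 (within the scatter), so the change does not carry over unaltered from one core to the other: the same change on two cores in this assay, a number 22 percentage points higher (beyond the scatter) from compound 1 to compound 2 and a number 2 percentage points lower (within the scatter) from compound 3 to compound 4, 24 percentage points apart, beyond the scatter of two such steps

With 2,4-dimethoxyphenyl held fixed, the group on the carbonyl carbon also shifts the read-out, with a number 17 percentage points lower from compound 2 to compound 4 (beyond the scatter). Two instances show that the result of this change depends on its surroundings in these four compounds, but they give neither a reason nor a rule for other cores.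

Open, from the compounds shown here alone, is how the same change reads with other groups on the carbonyl carbon, such as a carboxylic acid or a longer chain. Also open, going by these compounds, is whether an amine on the saturated ring carbon would follow either core.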